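Replacing the morpholinylcarbonyl on the aromatic nitrogen

The compounds below may be only part of what the source reports. "The series", "measured", "known", "first", "only" and "open" are said of these compounds alone.

Of the compounds shown here, two have been measured in an assay for inhibition of MAP kinase-interacting serine/threonine-protein kinase 2 (Homo sapiens), read by luminescence and ADP-Glo, with a stated time of 2 h; a higher number here means a weaker inhibitor, a lower number a stronger inhibitor. Compound 1 `O=c1ccc(-c2ccc3cn[nH]c3c2)cn1Cc1ccccc1C(F)(F)F`, which carries a benzyl bearing a trifluoromethyl on the aromatic nitrogen, gives 100 nM. Compound 2 `O=C(N1CCOCC1)n1cc(-c2ccc3cn[nH]c3c2)ccc1=O` reaches only the limit of > 2000 nM in this assay, a reading that sits at the limit of > 2000 nM in this assay, at which 1 of the 2 values shown sits, so for compound 2 only a range is known and no number. The two are not compared further, since they differ in more than one place.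

Compound 3 `O=c1ccc(-c2ccc3cn[nH]c3c2)cn1Cc1cccc(F)c1` follows from compound 2 by 3-fluorobenzyl in place of (morpholin-4-yl)carbonyl on an aromatic nitrogen. With compound 2 at a limit, the size of the step cannot be fixed, but it is expected to run toward stronger inhibition and well beyond the scatter, as an at least 13-fold lower number from compound 2 to compound 3 (1.12 log units; beyond the scatter). The expectation rests on compound 1, whose benzyl on the same aromatic nitrogen gives 100 nM. Compound 3 is therefore estimated at 150 nM in this assay, within 40 nM to 600 nM.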

Compound 3, half-maximal inhibitory concentration: 38 nM
Compound 3: middle estimate off by 3.9-fold (0.60 log units), on the high side; measured number outside the range, below it.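

On the aromatic nitrogen in this assay, 3-fluorobenzyl in place of (morpholin-4-yl)carbonyl gives an at least 52-fold lower number from compound 2 to compound 3 (1.72 log units; beyond the scatter). The size of this step is only a lower bound, as compound 2 stands at a limit and has no number: the limit of > 2000 nM in this assay, at which 1 of the 3 values shown sits. Compound 1 gives 100 nM and compound 3 gives 38 nM, so both benzyl groups shown on this nitrogen return measured numbers, with compound 2 as the one carbonyl-linked group shown.

The compounds shown leave open what an unsubstituted benzyl, a 4-fluorobenzyl or a plain alkyl chain would give on this nitrogen. They also leave open whether the carbonyl or the morpholine ring of compound 2 accounts for the difference, which an amine-bearing chain without the carbonyl could begin to separate.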